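This account rests on a few compounds, and the source may have more. Where it says the series, first, only, none or still open, it means among the compounds named here.

Working notes on the series in an assay on isolated protein for inhibition of Indoleamine 2,3-dioxygenase 1 (Homo sapiens), read by HPLC, with a stated time of 1.5 h; a higher number here means a weaker inhibitor, a lower number a stronger inhibitor.

Three compounds share one core and differ only in the aryl group on the carbon with a double bond to nitrogen. Compound 1 `O=[N+]([O-])c1ccc(N/C(=N\O)c2ccccc2F)c2nonc12` gives 56 nM in this assay. Compound 2 `O=[N+]([O-])c1ccc(N/C(=N\O)c2ccccc2Br)c2nonc12` gives 64 nM. For the measured compounds named here, compound 3 `O=[N+]([O-])c1ccc(N/C(=N\O)c2ccc(F)cc2)c2nonc12` gives 60 nM; on the three numbers so far compound 3 sits second highest, with compound 2 nearest and compound 1 furthest, both gaps within the scatter. The steps run a 1.1-fold higher number from compound 1 to compound 2 (0.06 log units; within the scatter), a 1.1-fold higher number from compound 1 to compound 3 (0.03 log units; within the scatter) and a 1.1-fold lower number from compound 2 to compound 3 (0.03 log units; within the scatter), so swapping fluoro for bromo and moving the halogen around the ring have left this assay flat.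

Compound 4 `O=[N+]([O-])c1ccc(N/C(=N\O)c2ccc(F)c(Br)c2)c2nonc12` is the next step from compound 3: bromo in place of hydrogen on an aromatic carbon, entering on an aromatic carbon of a six-membered aromatic ring of carbon only, ortho to a fluoro group and meta to a large group. The measured step that bears on it most directly is the halogen exchange, a 1.1-fold higher number from compound 1 to compound 2 (0.06 log units; within the scatter), which stayed within the scatter; the ring-position moves did likewise. Going by the values given here, no beyond-scatter step is therefore expected in this assay, in either direction, and the estimate for compound 4 is 65 nM, with a range of 30 nM to 140 nM, meaning an expected step of a 1.1-fold higher number from compound 3 to compound 4 (0.03 log units; within the scatter).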

Compound 4, half-maximal inhibitory concentration: 106 nM
Compound 4: the middle estimate sits 1.6-fold (0.21 log units) below what was measured, within the range that was stated.
By their numbers in this assay, from the lowest: compounds 1, 3, 2 and 4 (each within the scatter of the next).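

Compound 4 is the only compound shown with two halogens on the aryl ring, and in this assay bromo on the aromatic carbon ortho to a fluoro group and meta to a large group gives a 1.8-fold higher number from compound 3 to compound 4 (0.25 log units; within the scatter) so this place takes the added bromine with no step beyond the scatter. The comparisons with the singly halogenated rings read the same way, with a 1.7-fold higher number from compound 2 to compound 4 (0.22 log units; within the scatter) and a 1.9-fold higher number from compound 1 to compound 4 (0.28 log units; within the scatter) so all four compounds remain within the scatter of one another and the flat picture extends from one halogen on the ring to two. Nothing measured alongside these numbers accounts for how this place behaves.

The compounds shown carry only fluoro and bromo on the aryl ring, so the response in this assay to an amine, a carboxylic acid or a longer chain at this place stays open. Also open is how bromo at this place reads on its own: every compound shown with bromo here also has the fluoro group on the same ring.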